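From a Difluoro Link to a Fluorobenzyl Group

The source may hold more compounds than are shown below. What is called first, only, known or untested is meant among the compounds shown, and "the series" means these compounds.

Compound 2, with the structure `N#Cc1cc2c(nc1N1CCC(C(=O)NS(=O)(=O)C(F)(F)c3ccccc3)CC1)COC2=O`, carries a difluoro(phenyl)methyl group on the sulfonyl sulfur of its acylsulfonamide. In a functional assay (Platelet, plasma) for inhibition, with Homo sapiens as the target (on this read-out higher numbers stand for weaker inhibition and lower numbers for stronger inhibition), compound 2 has "not determined" (no result reported), so no number places it on the scale of inhibition. Two neighbours on the same scaffold give some footing. Compound 1, `N#Cc1cc2c(nc1N1CCC(C(=O)NS(=O)(=O)Cc3ccc(Cl)cc3)CC1)COC2=O`, in this assay gives 4420 nM. Compound 3, `CC1OC(=O)c2cc(C#N)c(N3CCC(C(=O)NS(=O)(=O)c4ccc(Cl)s4)CC3)nc21`, is reported only as a limit of this assay, > 300000 nM. That limit, (the limit of > 300000 nM in this assay, at which 1 of the 3 values shown sits), marks the weak end of what the assay can report.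

Compound 4, `N#Cc1cc2c(nc1N1CCC(C(=O)NS(=O)(=O)Cc3ccccc3F)CC1)COC2=O`, is the next step, and it differs from compound 2 in one place: 2-fluorobenzyl in place of difluoro(phenyl)methyl on a sulfonyl sulfur. Because compound 2 has no number, the size of this step cannot be read from measurements. The expectation rests instead on compound 1, which shares the core and also carries a benzyl-type group on that sulfur, with a halogen on its ring. Exchanging one ring halogen for another is expected to shift this assay by no more than its usual scatter, in no firm direction. Compound 4 is therefore estimated at 5000 nM, with a range from 1500 nM to 20000 nM.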

Compound 4, half-maximal inhibitory concentration: 23700 nM
The estimate for compound 4 lay 4.7-fold (0.68 log units) below the measured number; measured number outside the range, above it.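

In this assay, for the compounds shown here, 2-fluorophenyl in place of 4-chlorophenyl on a saturated chain carbon bound to a sulfonyl sulfur gives a 5.4-fold higher number from compound 1 to compound 4 (0.73 log units; beyond the scatter), which means weaker inhibition, and this is the only measured step at this position. It shows that the ring of this benzyl-type group is not a silent part of the molecule: on an unchanged core, a change limited to the halogen on that ring moves the read-out beyond the usual scatter. The step changes the identity of the halogen and its place on the ring together, and nothing measured here gives a reason for the weaker inhibition.

Steps involving compound 2 cannot be read, as it has no number, so the effect of the difluoro link on the sulfonyl sulfur stays unknown. Also open, on these data alone, are which of the two ring changes carries the step, and where a ring bearing an amine or a carboxylic acid, or a longer chain between the sulfur and the ring, would fall on this scale.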